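Cyano for chloro on a non-cytotoxic anilide pair

This account rests on a few compounds, and the source may have more. Where it says the series, first, only, none or still open, it means among the compounds named here.

The two measured compounds, compound 1 `CCS(=O)(=O)Nc1ccc(NC(=O)c2ccc(C#N)cc2)cc1C` and compound 2 `CCS(=O)(=O)Nc1ccc(NC(=O)c2ccc(Cl)cc2)cc1OC`, were both tested in an ADME assay on HEK293 cells (Homo sapiens) for cytotoxicity, read by MTT assay, with a stated time of 48 h; on this read-out lower numbers stand for stronger inhibition and higher numbers for weaker inhibition. Compound 1 gives only a limit of the assay, > 250000 nM. Compound 2 likewise gives only a limit, > 250000 nM. Compound 2 thus stands at the limit of > 250000 nM in this assay, at which 2 of the 2 values shown sit, and nothing in the numbers sets it apart from compound 1; the two differ in more than one place, so the values show only that neither reaches a measurable concentration. The unmeasured compound 3 `CCS(=O)(=O)Nc1ccc(NC(=O)c2ccc(C#N)cc2)cc1OC` is reached from compound 2 by one change: cyano in place of chloro on an aromatic carbon. Within the data shown here, no measured step of that kind is available, so no size or direction can be drawn from the data. Since compound 2 sits at a limit, a step that the limit leaves unreadable from compound 2 to compound 3 is expected to be none beyond the scatter, and compound 3 is estimated to give 300000 nM, within 100000 nM to 1000000 nM.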

Compound 3, half-maximal inhibitory concentration: > 250000 nM
Compound 3 was reported as a limit; the forecaster's own chance of this, stated with the estimate: 85%; the middle value does not contradict the limit.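

Among these compounds, compound 1, compound 2 and compound 3 all sit at a limit in this assay and no step among them can be read, neither chloro to cyano nor methyl to methoxy: the limit of > 250000 nM in this assay, at which 3 of the 3 values shown sit. The compounds shown leave open whether either change has any effect in this assay.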